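Swapping a methyl for a methoxy on the aniline ring

The source may hold more compounds than are shown below. What is called first, only, known or untested is meant among the compounds shown, and "the series" means these compounds.

Measured compounds:
- compound 1, `Brc1ccc(NCc2nc3ccc(Br)cc3[nH]2)cc1`, 20%
- compound 2, `COc1ccc(NCc2nc3ccccc3[nH]2)cc1`, 26.6%
- compound 3, `Cc1ccc(NCc2nc3ccc(Br)cc3[nH]2)cc1`, 20%

In a functional assay on the whole organism (strain albino) for inhibition, with Rattus norvegicus as the target, read by paw edema, with a stated time of 60 min, at a dose of 100 mg/kg by the oral route (on this read-out lower numbers stand for less inhibition and higher numbers for more inhibition at the one dose given (going by the name of the read-out)), compound 3 gives 20%, the same number at the digits shown as compound 1 with 20%; together these two are the lowest of the three values. Compound 2, which carries a methoxy on the aniline ring and no bromo on the shared core, gives 26.6%, a gap to compound 3 that lies within the scatter of this kind of measurement.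

Compound 4, `COc1ccc(NCc2nc3ccc(Br)cc3[nH]2)cc1`, is not yet measured. It arises from compound 3 by methoxy in place of methyl on an aromatic carbon. Going by the values given here, the only measured step in one place, no change at the digits printed from compound 1 to compound 3 (within the scatter), shows that exchanging one small group on that aromatic carbon left the read-out unchanged within the scatter. Among the compounds with values here, no measured step pairs methyl against methoxy directly; compound 2 only shows that a methoxy on this ring, on a core without bromo, gives a value in the same neighbourhood. The step of a number 3 percentage points higher from compound 3 to compound 4 (within the scatter) is therefore expected to stay within the scatter. Compound 4 is expected to give 23% in this assay, in the range 12% to 34%.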

Compound 4, a percentage reported as inhibition, in the whole organism at one dose (the size of the read-out at that dose, not a potency): 13.3%
Beside the measured number, compound 4's estimate is 9.7 percentage points above it, and the stated range covers the measured number.
By their numbers in this assay, from the lowest: compounds 4, 1, 3 and 2 (each within the scatter of the next, the first and the last beyond it).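

In this assay, methoxy in place of methyl on the aromatic carbon para to a large group gives a number 6.7 percentage points lower from compound 3 to compound 4 (within the scatter) and methoxy in place of bromo on that same carbon gives a number 6.7 percentage points lower from compound 1 to compound 4 (within the scatter) so with the bromo core in place, these three groups give values that cannot be told apart. Going by these compounds alone, the one step beyond the scatter lies elsewhere: with methoxy kept, bromo in place of hydrogen on the shared core gives a number 13.3 percentage points lower from compound 2 to compound 4 (beyond the scatter) and this step is modest. Nothing measured here gives a reason for that step.

From the compounds shown here alone, whether the same bromo step appears with methyl or bromo on the aniline ring remains open. So does the read-out with an amine, a carboxylic acid or a longer chain such as butoxy at this position.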